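The source may report more compounds than this note shows. Statements on the series, on what has been measured and on what is new or still open speak of the compounds shown alone.

Compound 1 `C=CCn1ccc(-c2cc(Br)ccc2O)n1` and compound 2 `Oc1ccc(Br)cc1-c1ccn(-c2ccccc2)n1` share one core; compound 3 `C=CCc1ccc(OC)c(-c2ccn(CC=C)n2)c1` and compound 4 `C=CCc1ccc(OC)c(-c2ccn(-c3ccccc3)n2)c1` share another, and the difference between the two cores is not broken down here. In a functional assay on BV-2 cells (Mus musculus) for inhibition, read by Griess assay, with a stated time of 24 h (on this read-out lower numbers stand for stronger inhibition and higher numbers for weaker inhibition), compound 1 gives 112000 nM. Compound 2 reaches only the limit of this assay, > 200000 nM. The change phenyl in place of allyl on an aromatic nitrogen thus brings an at least 1.7-fold higher number from compound 1 to compound 2 (0.25 log units; that floor lies within the scatter). Compound 3 likewise sits at the limit of this assay, > 200000 nM. Compound 4 carries the same kind of change, (phenyl in place of allyl on an aromatic nitrogen); the surroundings differ only in that the ring atom two ring bonds away bears a large group rather than a group of 8 heavy atoms. Compound 4 is expected to stay at the limit, an estimated step that the limit leaves unreadable from compound 3 to compound 4, because compound 3 already sits at the limit of > 200000 nM in this assay, at which 2 of the 3 values shown sit, and the earlier step ran toward weaker inhibition. The estimate for compound 4 is 350000 nM.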

Compound 4, half-maximal inhibitory concentration: 8920 nM
Compound 4: the middle estimate sits 39-fold (1.59 log units) above what was measured, outside the stated range (below it).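

In this assay, phenyl in place of allyl on an aromatic nitrogen gives an at least 22-fold lower number from compound 3 to compound 4 (1.35 log units; beyond the scatter), so the change does not carry over with one size between the core of compound 1 and the core of compound 3: the same change on two cores in this assay, an at least 1.7-fold higher number (0.25 log units; that floor lies within the scatter) from compound 1 to compound 2 and an at least 22-fold lower number (1.35 log units; beyond the scatter) from compound 3 to compound 4, at least 40-fold (1.60 log units) apart, beyond the scatter of two such steps. Each step is only a floor, as compound 2 and compound 3 sit at a limit: the limit of > 200000 nM in this assay, at which 2 of the 4 values shown sit. The two pairs show that the outcome of this change depends on the core, but not which difference between the cores matters, and they set no rule for the series.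

Open, going by these compounds, is how a benzyl, a longer chain or an amine-bearing chain on that nitrogen would read on either core. Also open, on these data alone, is whether phenyl keeps its gain on the core of compound 3 with a carboxylic acid on the phenyl ring.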